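The source may report more compounds than this note shows. Statements on the series, on what has been measured and on what is new or still open speak of the compounds shown alone.

Measured compounds:

Compound 1, `Cc1ccc(S(=O)(=O)N2C=CNC(=O)[C@H]2CC(=O)N[C@@H]2CCCc3cc(CN4CCCCC4)ccc32)cc1`, gives 0.115 nM in an in vitro functional assay on cells for antagonist activity at B1 bradykinin receptor (Homo sapiens), read by luminescence and calcium flux, with a stated time of 2 h; a lower number here means a stronger inhibitor, a higher number a weaker inhibitor.
Compound 2, `COc1ccc2c(c1)CCCC2NC(=O)C[C@@H]1C(=O)NC=CN1S(=O)(=O)c1ccc(C)cc1`, gives 8.95 nM in this assay.
Compound 3, `Cc1cc(S(=O)(=O)N2C=CNC(=O)[C@H]2CC(=O)N2CC[C@H](N3CCCC3)C2)c(C)cc1Cl`, gives 19 nM in this assay.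

Among these three, compound 3 stands at the highest number, that is, it is the weakest inhibitor of the set. The gap from compound 3 to compound 2 is beyond the usual scatter, and the gap to compound 1 is far beyond it, so compound 3 is clearly the least potent of the three measured compounds.

Compound 4, `Cc1cc(S(=O)(=O)N2C=CNC(=O)[C@H]2CC(=O)N2CCCC(N(C)C)CC2)c(C)cc1Cl`, is not yet measured. It differs from compound 3 in one place: a group of 10 heavy atoms (8 carbon, 2 nitrogen; one seven-membered non-aromatic ring with 1 hetero atom) in place of a group of 10 heavy atoms (8 carbon, 2 nitrogen; 2 five-membered non-aromatic rings with 1 hetero atom each), on a carbonyl carbon. Both groups carry the same count of heavy atoms, the same count of nitrogen atoms and a single hydrogen-bond acceptor, but the two five-membered rings of compound 3 give way to one seven-membered ring, and the defined stereocentre of that group is lost.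

Going by the values given here, no pair of measured compounds shows a change of this kind, so there is nothing to anchor the size of the step. The amide substituent is altered while the rest of the molecule stays as in compound 3. The expectation is that the step from compound 3 to compound 4 in this assay will be small, a 1.8-fold higher number from compound 3 to compound 4 (0.27 log units; within the scatter), most likely toward a somewhat weaker inhibitor, and possibly not beyond the scatter. On that basis compound 4 is estimated at 35 nM, with a range from 8 nM to 150 nM.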

Compound 4, half-maximal inhibitory concentration: 2.7 nM
The estimate for compound 4 lay 13-fold (1.11 log units) above the measured number; the whole stated range lies above it.
By their numbers in this assay, from the lowest: compound 1; then compound 4; then compound 2; then compound 3.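

In this assay, the group on the carbonyl carbon proves to be a place where the number moves even when the counts stay the same: the one seven-membered non-aromatic ring with 1 hetero atom, in place of the 2 five-membered non-aromatic rings with 1 hetero atom each, gives a 7.0-fold lower number from compound 3 to compound 4 (0.85 log units; beyond the scatter), with equal counts of heavy atoms, nitrogen atoms and hydrogen-bond acceptors on both sides. In this pair, then, the defined stereocentre of the leaving group is not required for a stronger inhibitor, and the arrangement of the same atoms matters beyond the scatter. No measurement at hand bears on why the number fell.

The change alters the ring system and removes the defined stereocentre in a single step, so the compounds shown cannot separate these two changes or say whether either alone would give the same result. As far as these compounds go, it also remains open how the seven-membered ring would behave if its dimethylamino group gave way to a diethylamino group or a morpholine.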